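Swapping the Pendant Ring on Two Inactive Compounds

The source may report more compounds than this note shows. Statements on the series, on what has been measured and on what is new or still open speak of the compounds shown alone.

Compound 1 `COc1cc(-c2ccc3ncn(-c4cc(OC)c(OC)c(OC)c4)c3c2)cc(OC)c1OC` and compound 2 `COc1cc(-n2cnc3ccc(-c4ccccc4Cl)cc32)cc(OC)c1OC` share one core and differ in the ring attached to it. In a functional assay on MCF7 cells (Homo sapiens) for antiproliferative activity, read by MTT assay, with a stated time of 72 h (a lower number here means a stronger inhibitor, a higher number a weaker inhibitor), compound 1 reaches only a limit of the assay, > 10000 nM. Compound 2 likewise gives only a limit in this assay, > 10000 nM. Among the compounds with values here, every value so far is the limit of > 10000 nM in this assay, at which 2 of the 2 values shown sit, so the numbers give no footing for a direction. Compound 3 `COc1cc(-n2cnc3ccc(-c4ccc(C)cc4)cc32)cc(OC)c1OC` carries 4-methylphenyl in place of 2-chlorophenyl on an aromatic carbon. From these two limits, the step that the limit leaves unreadable from compound 2 to compound 3 is expected to stay within the scatter, with another limit the most likely outcome. Compound 3 is therefore estimated at 15000 nM, within 3000 nM to 60000 nM.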

Compound 3, half-maximal inhibitory concentration: 110 nM
For compound 3 the middle estimate is 140-fold (2.13 log units) above the measured one, outside the stated range (below it).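

The pendant ring on this aromatic carbon can matter greatly: in this assay, 4-methylphenyl in place of 2-chlorophenyl gives an at least 90-fold lower number from compound 2 to compound 3 (1.95 log units; beyond the scatter). Within the data shown here, the shared core can therefore reach real activity against these cells, which the earlier compounds could not show. The step gives only a lower bound on the change, because compound 2 reaches only a limit of the assay: the limit of > 10000 nM in this assay, at which 2 of the 3 values shown sit.

The methyl group arrives and the chlorine leaves in one step, so the compounds shown leave open which of the two matters. A plain phenyl or a 4-chlorophenyl ring at this place would separate them.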